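The source may hold more compounds than are shown below. What is called first, only, known or untested is meant among the compounds shown, and "the series" means these compounds.

The measured compounds:
- compound 1, `CC(C)(C)c1ccc(Cn2cc(-c3cn([C@H]4C[C@H](O)[C@@H](CO)O4)c(=O)[nH]c3=O)nn2)cc1`: 96.9%
- compound 2, `CC(=O)OC[C@H]1O[C@@H](n2cc(-c3cc(C)no3)c(=O)[nH]c2=O)C[C@@H]1OC(C)=O`: 102%
- compound 3, `CC(C)(C)c1ccc(-c2cc(-c3cn([C@H]4C[C@H](O)[C@@H](CO)O4)c(=O)[nH]c3=O)on2)cc1`: 79.8%

All three were tested in a functional assay on HCT-15 cells (Homo sapiens) for cytotoxicity, read by sulforhodamine B assay, tested at 10 uM; a lower number here means less inhibition, a higher number more inhibition at the concentration tested (going by the name of the read-out). Compound 2 gives the highest of the three numbers with 102%. Its nearest neighbour is compound 1, whose value of 96.9% lies within the usual scatter of repeated measurements, so the two cannot be told apart. Compound 3, with 79.8%, lies further off and beyond the scatter, so it does inhibit less than compound 2 at this concentration.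

The next compound is compound 4, `CC(=O)OC[C@H]1O[C@@H](n2cc(-c3cc(-c4ccccc4)no3)c(=O)[nH]c2=O)C[C@@H]1OC(C)=O`, which has not yet been measured. It differs from compound 2 in one place: phenyl in place of methyl on an aromatic carbon. Cut one bond further out, the same change reads 3-methyl-1,2-oxazol-5-yl to 3-phenyl-1,2-oxazol-5-yl; the rest of the molecule is the shared core unchanged.

Going by the values given here, no two measured compounds differ in only one place, so no measured step can be carried over. Because compound 2 already reaches 102% there is little room to go up. Compound 4 is therefore expected to stay within the scatter of compound 2, with an expected step of a number 12 percentage points lower from compound 2 to compound 4 (beyond the scatter) in this assay, and if a shift appears, a drop is the likelier direction. The estimate for compound 4 is 90%, in the range 55% to 105%.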

Compound 4, a percentage reported as inhibition, at one concentration (the size of the read-out at that concentration, not a potency): 92.2%
The estimate for compound 4 lay 2.2 percentage points below the measured number; the measured number falls inside the stated range.
By their numbers in this assay, from the lowest: compound 3; then compounds 4, 1 and 2 (each within the scatter of the next).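

Going by these compounds alone, putting phenyl in place of methyl on this aromatic carbon, next to the ring nitrogen of the five-membered ring, gives the first single-change comparison in this set: in this assay there is a number 9.8 percentage points lower from compound 2 to compound 4 (within the scatter). The entering group brings 6 heavy atoms and a six-membered aromatic ring where the methyl brought 1 heavy atom and no ring, so this position accepts a much larger carbon-only group without a change that can be told from ordinary measurement scatter. Nothing measured here offers a reason for this outcome.

The compounds shown leave open whether a group of a different kind at this position, such as an amine or a carboxylic acid, or a group added to the new phenyl ring, such as a methoxy group, would keep the inhibition at this level. Since the read-out comes from a single concentration, it also leaves open whether the methyl and phenyl compounds would still match at lower concentrations, where one of them could show a stronger effect than the other.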